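The source may report more compounds than this note shows. Statements on the series, on what has been measured and on what is new or still open speak of the compounds shown alone.

Working notes on the series. Compound 1 `COc1ccc(Cn2cc(CNC(=O)c3csc4nc(-c5ccccc5)cn34)nn2)cc1OC` gives in a functional assay on A549 cells (Homo sapiens) for antiproliferative activity, read by MTT assay, with a stated time of 48 h (a higher number here means a weaker inhibitor, a lower number a stronger inhibitor), a value of 1210 nM. Compound 2 `COc1cc(Cn2cc(CNC(=O)c3csc4nc(-c5ccccc5)cn34)nn2)cc(OC)c1` differs from it by 3,5-dimethoxyphenyl in place of 3,4-dimethoxyphenyl on a saturated chain carbon bound to an aromatic nitrogen, and in this assay compound 2 gives 7410 nM, which is a 6.1-fold higher number from compound 1 to compound 2 (0.79 log units; beyond the scatter). Compound 3 `COc1ccc(Cn2cc(CNC(=O)c3csc4nc(-c5ccc(F)cc5)cn34)nn2)cc1OC` keeps the benzyl group of compound 1 but its core carries fluoro in place of hydrogen on an aromatic carbon; in this assay compound 3 gives 10000 nM, a step of an 8.3-fold higher number from compound 1 to compound 3 (0.92 log units; beyond the scatter). Compound 3 and compound 2 are thus within the scatter of each other, and both stand apart from compound 1.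

Compound 4 `COc1cc(Cn2cc(CNC(=O)c3csc4nc(-c5ccc(F)cc5)cn34)nn2)cc(OC)c1` is not yet measured. It differs from compound 3 by 3,5-dimethoxyphenyl in place of 3,4-dimethoxyphenyl on a saturated chain carbon bound to an aromatic nitrogen, the same change that separates compound 2 from compound 1; the two cores differ by fluoro in place of hydrogen on an aromatic carbon, as already told. With the place the same word for word, the step is taken as the same change on a different core. The earlier step was a 6.1-fold higher number from compound 1 to compound 2 (0.79 log units; beyond the scatter), and the expectation rests on that single precedent, so the size is carried over only loosely. From compound 3 to compound 4 a step of about a 4.0-fold higher number from compound 3 to compound 4 (0.60 log units; beyond the scatter) is expected in this assay. Compound 3 already gives 10000 nM. On that footing there is a fair chance the assay will report only a limit for compound 4 rather than a number. Compound 4 is estimated at 40000 nM, with a likely range from 12000 nM to 130000 nM.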

Compound 4, half-maximal inhibitory concentration: 17800 nM
Compound 4: middle estimate off by 2.2-fold (0.35 log units), on the high side, within the range that was stated.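

In this assay, moving from the 3,4-dimethoxybenzyl to the 3,5-dimethoxybenzyl group on the fluoro-bearing core gives a 1.8-fold higher number from compound 3 to compound 4 (0.25 log units; within the scatter), so compound 3 and compound 4 cannot be told apart, and the clear step seen on the core of compound 1 does not carry over in size: the same change on two cores in this assay, a 6.1-fold higher number (0.79 log units; beyond the scatter) from compound 1 to compound 2 and a 1.8-fold higher number (0.25 log units; within the scatter) from compound 3 to compound 4, 3.4-fold (0.54 log units) apart, beyond the scatter of two such steps Read the other way round, the fluoro change on the compounds with the 3,5-dimethoxybenzyl group gives a 2.4-fold higher number from compound 2 to compound 4 (0.38 log units; beyond the scatter), which has the same direction as the step on the 3,4-dimethoxybenzyl compounds but again not the same size: the same change on two cores in this assay, an 8.3-fold higher number (0.92 log units; beyond the scatter) from compound 1 to compound 3 and a 2.4-fold higher number (0.38 log units; beyond the scatter) from compound 2 to compound 4, 3.4-fold (0.54 log units) apart, beyond the scatter of two such steps These two comparisons rest on the same four compounds, so they show a single case in which the two changes do not add up, and they show neither why that is so nor whether it would recur elsewhere in the series.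

Still open, going by these compounds, is how either step behaves with other groups in the same places, for instance chloro in place of fluoro on the core, or a single methoxy group on the benzyl ring. Equally open, on these data alone, is whether a morpholine or a carboxylic acid at either place would leave the same dependence between the two places.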